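A few compounds are considered here, and "the series" means these few. Any claim that something is new, unique, unknown or untested is made for them only; others in the source may bear on it.

Compound 1, with the structure `COc1ccc2oc(-c3cn4nc(OC)sc4n3)cc2c1`, serves as the smaller of the two measured compounds in this set. In an ADME assay on microsomes from liver (Homo sapiens) for metabolic stability, with a stated time of 10 min (on this read-out higher numbers stand for a more stable compound and lower numbers for a less stable compound), compound 1 gives 30%. Compound 2, with the structure `COc1cc(OCc2ccccc2OC)c2cc(-c3cn4nc(OC)sc4n3)oc2c1`, carries an additional substituent on the shared core, and in this assay compound 2 gives 82%. Of the two numbers recorded, compound 2 stands highest; its nearest neighbour is compound 1, which lies lower by a margin that is beyond the usual scatter of such repeated measurements.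

Compound 3, with the structure `COc1cc(OCc2ccccc2OCc2ccccc2)c2cc(-c3cn4nc(OC)sc4n3)oc2c1`, has not yet been measured. It differs from compound 2 by a single counted change: phenyl in place of hydrogen on a saturated chain carbon bound to an oxygen on an aromatic ring. Going by the values given here, no step between two measured compounds mirrors this change, so the expectation rests on the position of compound 2 alone. The step is expected to run downward from compound 2 and to be moderate in size, namely a number 17 percentage points lower from compound 2 to compound 3 (beyond the scatter). For compound 3 in this assay a value of 65% is expected, with a range from 40% to 85%.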

Compound 3, percent of the compound remaining: 94%
Compound 3: middle estimate off by 29 percentage points, on the low side; measured number above the stated range.
By their numbers in this assay, from the lowest: compound 1; then compound 2; then compound 3.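

The exchange of hydrogen for phenyl on a saturated chain carbon bound to an oxygen on an aromatic ring, which turns methoxy into benzyloxy, gives in this assay a number 12 percentage points higher from compound 2 to compound 3 (beyond the scatter). Going by these compounds alone, this is the first step in the set that can be read to a single change, since the earlier compounds offered no pair differing in one place, and it shows that at this position a phenyl with its 6 heavy atoms goes with a higher number on this read-out, not a lower one. Nothing available accounts for this rise, so the step stands as an observation without an explanation.

The compounds shown leave open whether this upward step belongs to the phenyl ring as such or would also appear with other groups at this carbon, such as a longer chain, an amine or a carboxylic acid on the phenyl. Going by these compounds, they also rest on one pair on one core, so whether the same change would give a similar step on another compound remains unknown.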